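The compounds below may be only part of what the source reports. "The series", "measured", "known", "first", "only" and "open" are said of these compounds alone.

Compound 1 `CCC[C@@H]1O[C@H](COCc2ccc3ccccc3c2)[C@@H](OCc2ccc3ccccc3c2)[C@H](OCc2ccc3ccccc3c2)[C@H]1O` in a functional assay on HOS cells (Homo sapiens) for antiproliferative activity, read by sulforhodamine B assay (on this read-out lower numbers stand for stronger inhibition of growth and higher numbers for weaker inhibition of growth), gives only the limit > 50000 nM.
Compound 2 `CCC[C@@H]1O[C@H](COCc2ccc3ccccc3c2)[C@@H](OCc2ccc3ccccc3c2)[C@H](OCc2ccc3ccccc3c2)[C@H]1OC(C)=O` in this assay likewise gives only the limit > 50000 nM.
Among the measured compounds shown here, compound 3 `C=CC[C@@H]1O[C@H](COCc2ccccc2)[C@@H](OCc2ccccc2)[C@H](OCc2ccccc2)[C@H]1O` in this assay gives 44100 nM, the single number measured so far.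

Between compound 1 and compound 2 the change is acetyl in place of hydrogen on an oxygen on a saturated carbon; it made a step that the two limits leave unreadable from compound 1 to compound 2, because both sit at the limit of > 50000 nM in this assay, at which 2 of the 3 values shown sit. Compound 4 `C=CC[C@@H]1O[C@H](COCc2ccccc2)[C@@H](OCc2ccccc2)[C@H](OCc2ccccc2)[C@H]1OC(C)=O` carries the same change on the core of compound 3, namely (acetyl in place of hydrogen on an oxygen on a saturated carbon); the place is the same word for word, so this is the same change. The difference between the two cores is not broken down here.

The step from compound 3 to compound 4 is expected to be a 1.2-fold higher number from compound 3 to compound 4 (0.10 log units; within the scatter), resting on compound 3 already giving the weak value 44100 nM and on the earlier step being unreadable. Compound 4 is therefore estimated at 55000 nM, between 20000 nM and 150000 nM.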

Compound 4, concentration for 50% growth inhibition: 11000 nM
Beside the measured number, compound 4's estimate is 5.0-fold (0.70 log units) above it, and the stated range ends above it.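

In this assay, putting acetyl in place of hydrogen on the core of compound 3 gives a 4.0-fold lower number from compound 3 to compound 4 (0.60 log units; beyond the scatter), so on this core the hydroxy to acetoxy change brings a modest gain in growth inhibition. The same change on the core of compound 1 cannot be read, because compound 1 and compound 2 both give only a limit and not a number: the limit of > 50000 nM in this assay, at which 2 of the 4 values shown sit. The change has therefore been read on one core only, which shows neither that its effect carries over from one core to the other nor that it fails to.

The compounds shown leave open how a longer acyl chain such as butanoyl, or an amine in place of the acetoxy, would behave on either core.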